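Fluorobenzyloxy Series: Working Notes Toward Compound 3

The compounds below may be only part of what the source reports. "The series", "measured", "known", "first", "only" and "open" are said of these compounds alone.

Of the compounds shown here, two sharing one core have been measured in a functional assay on Mahlavu cells (Homo sapiens) for antiproliferative activity, read by sulforhodamine B assay, with a stated time of 72 h; on this read-out lower numbers stand for stronger inhibition and higher numbers for weaker inhibition. Compound 1 `FC(F)(F)c1ccc(CN2CCN(Cc3cc(-c4ccc(OCc5cccc(Cl)c5)cc4)on3)CC2)cc1` gives 4100 nM in this assay. Compound 2 `Fc1cccc(COc2ccc(-c3cc(CN4CCN(Cc5ccc(C(F)(F)F)cc5)CC4)no3)cc2)c1` gives 2900 nM in this assay. Among the compounds with values here, the single measured step, a 1.4-fold lower number from compound 1 to compound 2 (0.15 log units; within the scatter), involves fluoro in place of chloro on an aromatic carbon and falls within the usual scatter, so compound 2 and compound 1 cannot be told apart on these numbers; compound 2 simply stands beside compound 1, the only other member measured.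

Compound 3 `Fc1ccc(COc2ccc(-c3cc(CN4CCN(Cc5ccc(C(F)(F)F)cc5)CC4)no3)cc2)cc1` differs from compound 2 by 4-fluorophenyl in place of 3-fluorophenyl on a saturated chain carbon bound to an oxygen on an aromatic ring. Within the data shown here, no measured step covers a move of the fluorine around the ring; the one available step, a 1.4-fold lower number from compound 1 to compound 2 (0.15 log units; within the scatter), concerns a halogen exchange at the same place and was within the scatter. With nothing pointing in either direction, the step from compound 2 to compound 3 in this assay is expected to stay within the scatter, a 1.0-fold higher number from compound 2 to compound 3 (0.01 log units; within the scatter). Compound 3 is therefore estimated at 3000 nM in this assay, with a range from 1200 nM to 7500 nM.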

Compound 3, half-maximal inhibitory concentration: 3100 nM
Beside the measured number, compound 3's estimate is 1.0-fold (0.01 log units) below it, within the range that was stated.
By their numbers in this assay, from the lowest: compounds 2, 3 and 1 (each within the scatter of the next).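

In this assay, within the data shown here, there is a 1.1-fold higher number from compound 2 to compound 3 (0.03 log units; within the scatter) when the fluorine moves from 3-fluorobenzyl to 4-fluorobenzyl, the first reading at this position on where the halogen sits on the ring, and this step gives no basis for telling the two groups apart. A wider change at the same place, with a 1.3-fold lower number from compound 1 to compound 3 (0.12 log units; within the scatter) for 4-fluorophenyl in place of 3-chlorophenyl, also gives no separation, so changing the halogen and its ring position together shows no measurable effect across these three compounds. No measurement is available that would account for how closely these compounds read.

As far as these compounds go, whether this position tolerates anything beyond a single halogen on the benzyl ring remains open, since an unsubstituted benzyl, a methoxy-substituted benzyl or a longer chain carrying the same ring could read quite differently. From the compounds shown here alone, the trifluoromethyl group is also the same in all three compounds, so the effect of replacing it with a nitrile or a carboxylic acid remains unknown.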